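Sulfone to fluorinated sulfoxide on the aryl ring

A few compounds are considered here, and "the series" means these few. Any claim that something is new, unique, unknown or untested is made for them only; others in the source may bear on it.

Compound 1 `CC(C)OC(=O)N1CCC(Oc2ncnc3c2CCN3c2ccc(S(C)(=O)=O)cc2)CC1` is the reference point; in a functional assay on CHO-K1 cells with Glucose-dependent insulinotropic receptor (Homo sapiens) as the target, read by a luciferase reporter, with a stated time of 5 h (on this read-out higher numbers stand for larger maximal responses and lower numbers for smaller maximal responses), compound 1 gives 154%, the highest of the three numbers recorded. Among the compounds with values here, compound 2 `CC(C)SC(=O)N1CCC(Oc2ncnc3c2CCN3c2ccc(S(C)(=O)=O)cc2F)CC1` gives 138% and compound 3 `CS(=O)(=O)c1ccc(N2CCc3c(OC4CCN(C5=NCCCN5)CC4)ncnc32)c(F)c1` gives 66%; the only single-place step, a number 72 percentage points lower from compound 2 to compound 3 (beyond the scatter), concerns the amine nitrogen and not the aryl group. Compound 4 `CC(C)OC(=O)N1CCC(Oc2ncnc3c2CCN3c2ccc([S@+](C)[O-])c(F)c2)CC1` differs from compound 1 at the aryl group: a group of 10 heavy atoms (7 carbon, 1 oxygen, 1 fluorine, 1 sulfur; one six-membered aromatic ring of carbon only) in place of a group of 10 heavy atoms (7 carbon, 2 oxygen, 1 sulfur; one six-membered aromatic ring of carbon only), on a nitrogen on an aromatic ring in a ring. Within the data shown here, no measured pair isolates this change, and the one step recorded sits elsewhere, so no direct precedent exists. The entering group carries one fewer hydrogen-bond acceptor and a defined stereocentre. On that basis compound 4 is expected to stay in the same region as compound 1, with the estimated step of a number 24 percentage points lower from compound 1 to compound 4 (beyond the scatter) modest and downward, giving an estimate of 130% within 80% to 170%.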

Compound 4, largest response reached (reported as percent of maximum), in percent of the reference or control that the assay uses: 122%
Beside the measured number, compound 4's estimate is 8 percentage points above it; the range from low to high includes it.
By their numbers in this assay, from the lowest: compound 3; then compound 4; then compound 2; then compound 1.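

In this assay, the aryl group on the nitrogen on an aromatic ring is a position where the read-out responds, with a number 32 percentage points lower from compound 1 to compound 4 (beyond the scatter). Within the data shown here, the earlier step concerned only the amine nitrogen, so this is the first single-place reading at the aryl group. No available evidence bears on this step. Fluorine, sulfoxide and the defined stereocentre enter together, so their separate contributions remain open. Also open, as far as these compounds go, is how the response would shift with a nitrile or a carboxylic acid on this aryl group.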